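From a Lactam Side Chain to a Hydroxy Amine Tail

The source may report more compounds than this note shows. Statements on the series, on what has been measured and on what is new or still open speak of the compounds shown alone.

Three close relatives of one shared core have been tested in a functional assay (Homo sapiens) for antiproliferative activity, read by resazurin assay, with a stated time of 48 h, tested at 5 uM; on this read-out lower numbers stand for a weaker effect and higher numbers for a stronger effect at the one concentration tested. Compound 1 `COc1cc(OC)c2c(=O)cc(-c3ccc(OCCBr)cc3)oc2c1` is reported as "not active" (no number reported) and compound 2 `COc1cc(OC)c2c(=O)cc(-c3ccc(OCCF)cc3)oc2c1` as "not active" (no number reported), neither with a number attached. Compound 3 `COc1cc(OC)c2c(=O)cc(-c3ccc(OCCN4CCCC4=O)cc3)oc2c1` is the only one with a figure: in this assay compound 3 gives 7%, a small effect at the single concentration tested. Compound 4 `COc1cc(OC)c2c(=O)cc(-c3ccc(OCC(O)CN4CCCC4)cc3)oc2c1` differs from compound 3 in one place: 1-hydroxy-2-(pyrrolidin-1-yl)ethyl in place of (2-oxopyrrolidin-1-yl)methyl on a saturated chain carbon bound to an oxygen on an aromatic ring. Going by the values given here, no measured pair shows what such a swap does here, so the expected step in this assay is small, a number 5 percentage points higher from compound 3 to compound 4 (within the scatter), leaning slightly upward but staying within the usual scatter. Compound 4 is therefore estimated at about 12%, somewhere between 0% and 35%.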

Compound 4, a percentage reported as inhibition, at one concentration (the size of the read-out at that concentration, not a potency): 21%
For compound 4 the middle estimate is 9 percentage points below the measured one; the range from low to high includes it.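

In this assay, putting 1-hydroxy-2-(pyrrolidin-1-yl)ethyl in place of (2-oxopyrrolidin-1-yl)methyl gives a number 14 percentage points higher from compound 3 to compound 4 (beyond the scatter). Going by these compounds alone, this is the first measured sign that the side chain at this place can shift the read-out, although the step is modest. Nothing available here explains the rise.

The compounds shown leave open which part of the swap matters: the added hydroxy group, the lost ring carbonyl or the longer chain. As far as these compounds go, whether a piperidine ring in place of the pyrrolidine ring would raise the number further also stays open.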